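The compounds below may be only part of what the source reports. "The series", "measured", "known", "first", "only" and "open" are said of these compounds alone.

In a functional assay on SEM cells (Homo sapiens) for cytotoxicity, with a stated time of 72 h (a higher number here means that more compound is needed for the effect, a lower number that less compound is needed), compound 3 (`C=C[C@@](C)(/C=C/c1ccc(O)c(/C=C/C(=O)OCc2ccccc2)c1)CCC=C(C)C`) reads > 36600 nM as a limit of the assay, not a number. Compound 2 (`C=C[C@@](C)(/C=C/c1ccc(O)c(/C=C/C#N)c1)CCC=C(C)C`) reads > 36600 nM and that too is a limit. Among the measured compounds shown here, compound 1 (`C=C[C@@](C)(/C=C/c1ccc(O)c(/C=C/C(=O)c2ccccc2)c1)CCC=C(C)C`) gives 8000 nM as the one actual number. The series therefore rests on the limit of > 36600 nM in this assay, at which 2 of the 3 values shown sit, and that single number.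

Compound 4 (`C=C[C@@](C)(/C=C/c1ccc(O)c(/C=C/c2ccc(F)cc2)c1)CCC=C(C)C`) carries 4-fluorophenyl in place of benzyloxycarbonyl on a double-bonded chain carbon bound to a double-bonded chain carbon.

Three measured steps changed the group at this place. The first is an at least 4.5-fold higher number from compound 1 to compound 2 (0.66 log units; beyond the scatter) and the second is an at least 4.5-fold higher number from compound 1 to compound 3 (0.66 log units; beyond the scatter) and both lie beyond the scatter. The third is a step that the two limits leave unreadable from compound 2 to compound 3 and adds no size. Compound 4 keeps an aromatic ring at this place, as compound 1 and compound 3 do, yet those two differ, so the ring alone settles nothing. A modest move toward a lower number is expected, and a reading at the limit remains quite possible.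

The expected step is an at least 2.2-fold lower number from compound 3 to compound 4 (0.35 log units; beyond the scatter) and no larger. Compound 4 is estimated at 16000 nM with an expected range of 6000 nM to 45000 nM in this assay for now.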

Compound 4, half-maximal effective concentration: > 36600 nM
Compound 4: only a limit was reported (the forecaster's own chance of this, stated with the estimate: 40%); at least 2.2-fold (0.35 log units) between middle value and limit.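

Exchanging benzoyl for 4-fluorophenyl gives an at least 4.5-fold higher number from compound 1 to compound 4 (0.66 log units; beyond the scatter), so an aromatic ring on the chain without a carbonyl does not match compound 1 in this assay. Of the four groups shown at this place, only benzoyl yields an actual number: compound 1 gives 8000 nM. The steps among compound 2, compound 3 and compound 4 join limit to limit and cannot be read, and nitrile, benzyloxycarbonyl and 4-fluorophenyl now share one reading, which is a limit and not a number: the limit of > 36600 nM in this assay, at which 3 of the 4 values shown sit.

From the compounds shown here alone, whether the reading of compound 1 depends on the ketone carbonyl, on the phenyl ring it carries or on both stays open, and an acetyl group or an amide at this place would help separate the two parts. Also open, going by these compounds, is how far compound 2, compound 3 and compound 4 lie from one another, since their limits give no order among them.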